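Swapping the aryl group on the ring amine of compound 2

A few compounds are considered here, and "the series" means these few. Any claim that something is new, unique, unknown or untested is made for them only; others in the source may bear on it.

Compounds measured in a functional assay for antagonist activity at transient receptor potential cation channel subfamily V member 1 (Homo sapiens), read by FLIPR and calcium flux; on this read-out higher numbers stand for weaker inhibition and lower numbers for stronger inhibition:
compound 1, `O=C1CSc2ccc(NC(=O)C3CCN(c4cc(F)c(F)c(F)c4)CC3)cc2N1`, 1960 nM
compound 2, `O=C1COc2ccc(NC(=O)C3CCN(c4cc(F)c(F)c(F)c4)CC3)cc2N1`, 59 nM

Compound 2 gives the lowest of the two numbers in this assay. Its nearest neighbour is compound 1, whose number is higher by a margin that lies beyond the usual scatter, so compound 2 stands as the stronger inhibitor of the pair.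

Compound 3, `Cc1c(Cl)cccc1N1CCC(C(=O)Nc2ccc3c(c2)NC(=O)CO3)CC1`, has not yet been measured. It differs from compound 2 in one place: 3-chloro-2-methylphenyl in place of 3,4,5-trifluorophenyl on an amine nitrogen in a ring. The rest of the shared core, with its amide link and the ring bearing the amide nitrogen, is unchanged.

Among the measured compounds shown here, no measured pair here shows what such a change in the group on the ring amine does, so the step from compound 2 to compound 3 cannot be read from a precedent. The author expects compound 3 to stay close to compound 2, with a step of a 1.4-fold higher number from compound 2 to compound 3 (0.13 log units; within the scatter) in this assay that is not beyond the scatter. The estimated value for compound 3 in this assay is 80 nM, within a range from 20 nM to 350 nM.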

Compound 3, half-maximal inhibitory concentration: 100 nM
Compound 3: middle estimate off by 1.3-fold (0.10 log units), on the low side, within the range that was stated.
By their numbers in this assay, from the lowest: compounds 2 and 3 (each within the scatter of the next); then compound 1.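

In this assay, the change on the amine nitrogen in a ring gives a 1.7-fold higher number from compound 2 to compound 3 (0.23 log units; within the scatter), so the scatter does not separate the two compounds. At this position, therefore, 3-chloro-2-methylphenyl and 3,4,5-trifluorophenyl cannot be told apart by this read-out, even though three fluorine atoms leave and a chlorine and a methyl enter, which shows that this one aryl replacement, with a different set of substituents, leaves the number within the scatter of compound 2. Nothing measured here accounts for this match between the two aryl groups.

Going by these compounds, the chlorine and the methyl enter together in compound 3, so their separate contributions remain open, and a plain phenyl, a 3-chlorophenyl or a 2-methylphenyl on the same nitrogen would be needed to part them. On these data alone, it also remains open whether a pyridyl ring or a cyclohexyl group can stand in this place, and whether 3-chloro-2-methylphenyl would give a similar result on the core of compound 1.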